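The compounds below may be only part of what the source reports. "The series", "measured", "known", "first", "only" and "open" are said of these compounds alone.

Three compounds sharing one core have numbers in a functional assay on PC-3 cells (Homo sapiens) for cytotoxicity, read by MTT assay, with a stated time of 72 h; on this read-out higher numbers stand for weaker inhibition and lower numbers for stronger inhibition. There compound 1 `O=C(/C=C/c1ccc([N+](=O)[O-])cc1)Nc1cc2c(Nc3ccc(F)c(Cl)c3)ncnc2cc1O[C@H]1CCOC1` gives 22800 nM, compound 2 `COc1ccc(OC)c(/C=C/C(=O)Nc2cc3c(Nc4ccc(F)c(Cl)c4)ncnc3cc2OC)c1` gives 28600 nM, and compound 3 `COc1ccc(OC)c(/C=C/C(=O)Nc2cc3c(Nc4ccc(F)c(Cl)c4)ncnc3cc2O[C@H]2CCOC2)c1` gives 8730 nM. Compound 2 and compound 1 lie within the scatter of each other, and both stand above compound 3.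

The next compound, compound 4 `COc1cc(/C=C/C(=O)Nc2cc3c(Nc4ccc(F)c(Cl)c4)ncnc3cc2OC)cc(OC)c1`, departs from compound 2 in one group only: 3,5-dimethoxyphenyl in place of 2,5-dimethoxyphenyl on a double-bonded chain carbon bound to a double-bonded chain carbon. The two have the same atoms, joined differently, and the swap sits on a double-bonded chain carbon bound to a double-bonded chain carbon.

Among the measured compounds shown here, only one measured step touches that place: a 2.6-fold lower number from compound 1 to compound 3 (0.42 log units; beyond the scatter). It was modest, even though it exchanged 4-nitrophenyl for 2,5-dimethoxyphenyl. The other step, a 3.3-fold lower number from compound 2 to compound 3 (0.52 log units; beyond the scatter), was also modest, but it concerns the group on an oxygen on an aromatic ring and leaves 2,5-dimethoxyphenyl untouched, so it bears on this change only indirectly. For the measured compounds named here, no measured compound carries 3,5-dimethoxyphenyl, so the data fix no direction. The expected outcome is therefore no step beyond the scatter, and the estimated change is a 1.1-fold lower number from compound 2 to compound 4 (0.06 log units; within the scatter). In this assay the expected value for compound 4 is 25000 nM, with an estimated range from 10000 nM to 60000 nM.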

Compound 4, half-maximal inhibitory concentration: "not active" (no number reported)
The entry for compound 4 holds no number, and the estimate cannot be compared.
By their numbers in this assay, from the lowest: compound 3; then compounds 1 and 2 (each within the scatter of the next).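

In this assay, among the compounds shown here, compound 4 is entered as "not active" with no number, so no step from compound 2 to compound 4 can be read. No evidence at hand bears on this result. The compounds shown leave open how far 3,5-dimethoxyphenyl separates compound 4 from compound 2 on this read-out.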